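Transfer of a chloro step from compound 1 to compound 3

The source may hold more compounds than are shown below. What is called first, only, known or untested is meant among the compounds shown, and "the series" means these compounds.

Measured so far in an assay on CHO cells for displacement of a labelled ligand from adenosine receptor A3 (Homo sapiens), read by scintillation counting, tested at 10 uM; a lower number here means less inhibition, a higher number more inhibition at the concentration tested (going by the name of the read-out):
compound 1, `CC(C)(C)Cc1c(Br)sc(N)c1C(=O)c1ccc(Cl)cc1`, gives 1%
compound 2, `CC(C)(C)Cc1c(Br)sc(N)c1C(=O)c1ccc(Cl)c(Cl)c1`, gives 1%
compound 3, `COc1ccc(-c2sc(N)c(C(=O)c3cccc(Cl)c3)c2CC(C)(C)C)cc1`, gives 2%

Among the compounds with values here, all three measured compounds sit at the low end of the read-out, and no compound stands apart from the others: the value of compound 3 is within the scatter of compound 1 and of compound 2.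

One change is made twice in the series. From compound 1 to compound 2 it reads (chloro in place of hydrogen on an aromatic carbon), and the step it made is no change at the digits printed from compound 1 to compound 2 (within the scatter). From compound 3 to the unmeasured compound 4, `COc1ccc(-c2sc(N)c(C(=O)c3ccc(Cl)c(Cl)c3)c2CC(C)(C)C)cc1`, the change reads (chloro in place of hydrogen on an aromatic carbon). The two are the same kind of change, not the same: in compound 2 the entering chloro group is meta to a large group, in compound 4 it is para to a large group. How the core of compound 3 differs from the core of compound 1 is not broken down here.

For compound 4 the expected step in this assay is a number 1 percentage points higher from compound 3 to compound 4 (within the scatter), beside the earlier one. This rests on compound 1 to compound 2 having shown no change at the digits printed from compound 1 to compound 2 (within the scatter) and on compound 3 giving 2%, so that a value again within the scatter of the starting point is expected. The estimate for compound 4 is 3%, between 0% and 12%.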

Compound 4, a percentage reported as inhibition, at one concentration (the size of the read-out at that concentration, not a potency): 1%
The estimate for compound 4 lay 2 percentage points above the measured number, within the range that was stated.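

In this assay the chloro step has now been read on two cores, and the two readings agree: the same change on two cores in this assay, no change at the digits printed (within the scatter) from compound 1 to compound 2 and a number 1 percentage points lower (within the scatter) from compound 3 to compound 4, 1 percentage points apart, within the scatter of two such steps. On the second core the step reads a number 1 percentage points lower from compound 3 to compound 4 (within the scatter), here with the chloro entering para to a large group and ortho to a chloro group, and the exchange of bromo for 4-methoxyphenyl on the 3,4-dichlorophenyl compounds reads no change at the digits printed from compound 2 to compound 4 (within the scatter). This shows that the chloro change left the read-out at the low end on both cores, but it does not show that the change carries from one core to another in any wider sense: all four compounds sit at the floor of the read-out, where a real effect of the change in either direction would be hard to see, and a single concentration gives no potency.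

Going by these compounds, what remains open is whether any compound of this series rises clear of the low end of this assay, without which the transfer of a step cannot be tested properly. Also open, on these data alone, is the outcome with other groups at the place held by bromo or 4-methoxyphenyl, such as an amine, a carboxylic acid or a longer chain.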